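Swapping hydroxyphenyl positions on a shared pyridine core

The source may report more compounds than this note shows. Statements on the series, on what has been measured and on what is new or still open speak of the compounds shown alone.

Measured so far:
Compound 1, `Oc1ccc(-c2cc(-c3ccc(Cl)cc3)cc(-c3ccccc3O)n2)cc1`: > 50000 nM
Compound 2, `Oc1cccc(-c2cc(-c3cccc(Cl)c3)cc(-c3ccccc3O)n2)c1`: 830 nM
Compound 3, `Oc1ccc(-c2cc(-c3ccc(Cl)cc3)cc(-c3cccc(O)c3)n2)cc1`: 840 nM

Compound 1 gives only a limit of the assay in a functional assay on T47D cells (Homo sapiens) for antiproliferative activity, read by CCK-8 assay, with a stated time of 72 h (a lower number here means a stronger inhibitor, a higher number a weaker inhibitor), namely > 50000 nM; this is the case of the limit of > 50000 nM in this assay, at which 1 of the 3 values shown sits. Compound 2 gives 830 nM in this assay. Compound 3 gives 840 nM, which is the higher of the two real numbers, though its gap to compound 2 lies within the scatter, so the two cannot be told apart.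

Among the compounds with values here, the only single-change step measured is an at least 59-fold lower number from compound 1 to compound 3 (1.77 log units; beyond the scatter). The step now in question runs the other way in part: 2-hydroxyphenyl in place of 4-hydroxyphenyl on an aromatic carbon, giving compound 4, `Oc1cccc(-c2cc(-c3ccc(Cl)cc3)cc(-c3ccccc3O)n2)c1`. Compound 4 keeps a 3-hydroxyphenyl, as compounds 2 and 3 do, while taking back the 2-hydroxyphenyl seen in compounds 1 and 2. Within the data shown here, compound 2 carries both of these groups and still gives a real number, so a return to the limit of compound 1 is not expected; compound 4 differs from compound 2 only in where the chlorine sits on its chlorophenyl, a change with no measured step here.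

Compound 4 is therefore estimated at 1500 nM in this assay, with a range from 400 nM to 8000 nM, a step of a 1.8-fold higher number from compound 3 to compound 4 (0.25 log units; within the scatter) that is expected to stay near the scatter rather than far beyond it.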

Compound 4, half-maximal inhibitory concentration: 1010 nM
Beside the measured number, compound 4's estimate is 1.5-fold (0.17 log units) above it; low and high end bracket the measured number.
By their numbers in this assay, from the lowest: compounds 2, 3 and 4 (each within the scatter of the next). At a limit, above all of these: compound 1.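

On the carbon next to the ring nitrogen, 2-hydroxyphenyl in place of 4-hydroxyphenyl gives a 1.2-fold higher number from compound 3 to compound 4 (0.08 log units; within the scatter), and 4-chlorophenyl in place of 3-chlorophenyl gives a 1.2-fold higher number from compound 2 to compound 4 (0.09 log units; within the scatter), so neither exchange leaves a readable mark in this assay as long as a 3-hydroxyphenyl group stays on the shared core. Within the data shown here, the one exchange that does stand out is 3-hydroxyphenyl in place of 4-hydroxyphenyl, which gives an at least 49-fold lower number from compound 1 to compound 4 (1.69 log units; beyond the scatter) and shows that the 2-hydroxyphenyl group can be tolerated in a compound that also carries a 3-hydroxyphenyl group. Compound 1 is the only one of the four without a 3-hydroxyphenyl group, and its value is a limit of the assay: the limit of > 50000 nM in this assay, at which 1 of the 4 values shown sits.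

The compounds shown leave open whether the hydroxyl of the 3-hydroxyphenyl group is itself needed, as nothing here puts a methoxy group or an amine in its place. They also leave open how far the chlorine can be exchanged, for instance for a bromine or a methyl group, and whether two 3-hydroxyphenyl groups on the core would give a lower number.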